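From isopropyl to methyl on a sulfonamide nitrogen

A few compounds are considered here, and "the series" means these few. Any claim that something is new, unique, unknown or untested is made for them only; others in the source may bear on it.

Of the compounds shown here, three sharing one core have been read so far. In a physicochemical assay for solubility, in phosphate buffer, measured as kinetic solubility, with a stated time of 24 h, at pH 7.4 (on this read-out higher numbers stand for higher solubility and lower numbers for lower solubility), compound 1 (`CC(C)CN(Cc1ccc(N2CCN(NS(C)(=O)=O)CC2)cc1)S(=O)(=O)Cc1ccccc1`) gives <= 1000 nM, which is a limit of the assay. Compound 2 (`CC(=O)N1CCN(c2ccc(CN(CC(C)C)S(=O)(=O)Cc3ccccc3)cc2)CC1`) gives <= 1000 nM, again a limit. Compound 3 (`CC(=O)N1CCN(c2ccc(CN(C(C)C)S(=O)(=O)Cc3ccccc3)cc2)CC1`) gives <= 1000 nM, also a limit, so it stands without a number of its own. The whole set sits at one mark, (the limit of <= 1000 nM in this assay, at which 3 of the 3 values shown sit).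

Compound 4 (`CC(=O)N1CCN(c2ccc(CN(C)S(=O)(=O)Cc3ccccc3)cc2)CC1`) differs from compound 3 by methyl in place of isopropyl on a sulfonamide nitrogen, with methyl in place of isopropyl on a sulfonamide nitrogen. Among the measured compounds shown here, two measured steps bear on this. The closer one is a step that the two limits leave unreadable from compound 2 to compound 3, isopropyl in place of isobutyl on a sulfonamide nitrogen, the same kind of place. The other is a step that the two limits leave unreadable from compound 1 to compound 2, acetyl in place of methanesulfonamido on an amine nitrogen in a ring, a change of a different group. Neither has a size that can be read, so neither gives a direction. The estimate therefore rests on (the limit of <= 1000 nM in this assay, at which 3 of the 3 values shown sit). The expected change is a number no lower from compound 3 to compound 4 (the limit leaves the size open), with nothing foreseen beyond the scatter in this assay. Compound 4 is expected at 1000 nM, within an estimated range of 300 nM to 4000 nM.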

Compound 4, solubility: 7000 nM
For compound 4 the middle estimate is 7.0-fold (0.85 log units) below the measured one, and the stated range ends below it.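

In this assay, among the compounds shown here, the sulfonamide nitrogen proves to be a place where the group matters: methyl in place of isopropyl gives an at least 7.0-fold higher number from compound 3 to compound 4 (0.84 log units; beyond the scatter), the first step in the set that can be read. The same place gives a step of the same printed size when methyl is set against the isobutyl group, with an at least 7.0-fold higher number from compound 2 to compound 4 (0.84 log units; beyond the scatter), so both of these larger chains on that nitrogen stand on the lower side of methyl. Compound 4 is the only compound here with a number of its own, and the others stay at one mark: the limit of <= 1000 nM in this assay, at which 3 of the 4 values shown sit.

For the compounds shown here, the steps among the earlier compounds cannot be read, so it stays open whether isobutyl and isopropyl differ from each other and how large the rise to compound 4 really is. Also open, from the compounds shown here alone, are whether ethyl or a bare hydrogen on the sulfonamide nitrogen would give a higher or a lower number than methyl, and whether the rise with methyl holds when methanesulfonamido replaces acetyl on the amine nitrogen in a ring.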